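Fluorine for Amine on the Aryl Ketone of a Chalcone-Like Pyrazole

This account rests on a few compounds, and the source may have more. Where it says the series, first, only, none or still open, it means among the compounds named here.

Measured compounds and their numbers:
compound 1, `COc1cc(-c2cc(/C=C/C(=O)c3ccc(N)cc3)[nH]n2)cc(OC)c1OC`: 98%
compound 2, `COc1ccc(-c2cc(/C=C/C(=O)c3ccc(OC)c(OC)c3)[nH]n2)cc1`: 109%
compound 3, `COc1cc(C(=O)/C=C/c2cc(-c3cc(OC)c(OC)c(OC)c3)n[nH]2)cc(OC)c1OC`: 95%

Of the compounds shown here, three sharing a pyrazole-linked enone have been tested in a functional assay on SK-OV-3 cells (Homo sapiens) for cytotoxicity, read by sulforhodamine B assay, with a stated time of 48 h, tested at 0.1 uM; a lower number here means a stronger effect, a higher number a weaker effect of the compound at the concentration tested. Compound 1 gives 98%, which among the three numbers is the second highest. Compound 3 gives 95%, a number within the scatter of compound 1, so the two cannot be told apart. Compound 2 gives 109%, a number beyond the scatter and higher than that of compound 1. None of the three compounds shows a strong effect at the concentration tested.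

Compound 4, `COc1cc(-c2cc(/C=C/C(=O)c3ccc(F)c(F)c3)[nH]n2)cc(OC)c1OC`, has not yet been measured in this assay. It differs from compound 1 in one place: 3,4-difluorophenyl in place of 4-aminophenyl on a carbonyl carbon. For the measured compounds named here, no pair among the measured compounds differs in exactly this way, so there is no measured step to lean on. With compounds 1 and 3 sitting close together and compound 2 only modestly apart, a step of no more than the usual scatter is expected, in either direction. Compound 4 is therefore estimated to give 98%, with a range from 86% to 110%. This means an expected step of no change at the digits printed from compound 1 to compound 4 (within the scatter), which is not beyond the scatter.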

Compound 4, a percentage reported as activity, at one concentration (the size of the read-out at that concentration, not a potency): 99%
Compound 4: middle estimate off by 1 percentage points, on the low side; measured number inside the range.
By their numbers in this assay, from the lowest: compounds 3, 1, 4 and 2 (each within the scatter of the next, the first and the last beyond it).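

In this assay, for the compounds shown here, 3,4-difluorophenyl in place of 4-aminophenyl on a carbonyl carbon gives a number 1 percentage points higher from compound 1 to compound 4 (within the scatter), and this is the first step that can be read for a single change, as no earlier pair differed in one place only. The group that leaves carries a nitrogen with a hydrogen-bond donor and acceptor, while the group that enters carries two fluorines and neither of these, yet at this one concentration the read-out does not separate the two compounds, and neither shows a strong effect, so the step says little about how much this position matters once a clear effect is present. Nothing available bears on why the number stays within the scatter.

The compounds shown leave open whether a quite different group on that carbonyl carbon, such as a carboxylic acid or a longer chain, would move the number beyond the scatter. They also leave open whether compound 1 and compound 4 would still match at a higher concentration, where a stronger effect could appear.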